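Two aromatic arms on a shared core

The source may hold more compounds than are shown below. What is called first, only, known or untested is meant among the compounds shown, and "the series" means these compounds.

Compound 1, `C=CCn1c(=O)/c(=C\c2cccc(Cl)c2Cl)[nH]c(=O)/c1=C\c1ccccc1OC`, carries two aromatic arms on a shared core, one of them a 2,3-dichlorophenyl. In a functional assay on MOLT-4 cells (Homo sapiens) for cytotoxicity, read by CCK-8 assay, with a stated time of 72 h (on this read-out higher numbers stand for weaker inhibition and lower numbers for stronger inhibition), compound 1 gives 1200 nM. Within the data shown here, that is the only number in hand: compound 2, `COc1ccccc1/C=c1\c(=O)[nH]/c(=C/c2cccc(Cl)c2Cl)c(=O)n1C`, was also prepared, but in this assay compound 2 gives "not determined" (no result reported), so compound 1 stands alone and cannot be ranked against anything.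

Compound 3, `C=CCn1c(=O)/c(=C\c2cccc(C)c2)[nH]c(=O)/c1=C\c1ccccc1OC`, differs from compound 1 in one place: 3-methylphenyl in place of 2,3-dichlorophenyl on a double-bonded chain carbon bound to an aromatic carbon. Everything else in the molecule is unchanged.

Among the measured compounds shown here, no measured pair in this set shows what such a change does, so the expectation rests on compound 1 alone. With two chlorine atoms leaving and a single methyl entering, a modest loss of potency in this assay seems about as plausible as no change at all, and the expected step of a 1.7-fold higher number from compound 1 to compound 3 (0.22 log units; within the scatter) is taken as small, at or just beyond the usual scatter toward weaker inhibition, with wide uncertainty either way. Compound 3 is therefore estimated at 2000 nM, expected to lie between 600 nM and 8000 nM.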

Compound 3, half-maximal inhibitory concentration: 16000 nM
Beside the measured number, compound 3's estimate is 8.0-fold (0.90 log units) below it; the whole stated range lies below it.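

In this assay, putting 3-methylphenyl in place of 2,3-dichlorophenyl on a double-bonded chain carbon bound to an aromatic carbon gives a 13-fold higher number from compound 1 to compound 3 (1.12 log units; beyond the scatter), a large step well beyond the scatter, so what sits on this arm matters strongly for the read-out. The aromatic ring of carbon stays and the rest of the molecule is unchanged, with only two chlorine atoms leaving and a single methyl entering, so even this small edit is enough to weaken inhibition markedly. Nothing in the data available here accounts for the loss, and its cause remains unknown.

With a single pair, the loss cannot yet be assigned to the chlorine atoms leaving, to the methyl entering, or to both together. From the compounds shown here alone, it also remains open whether an amine or a carboxylic acid on this aromatic ring would recover the activity of compound 1, and whether the same swap would cost as much with a different group on the shared core.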